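The source may report more compounds than this note shows. Statements on the series, on what has been measured and on what is new or still open speak of the compounds shown alone.

Compound 1 `COc1cc(C2=NOC(c3c[nH]c4ccccc34)C2)cc(OC)c1OC` gives 5000 nM in a functional assay on LNCaP C4-2 cells (Homo sapiens) for inhibition, read by MTT assay, with a stated time of 48 h; a lower number here means a stronger inhibitor, a higher number a weaker inhibitor.
Compound 2 `c1ccc2c(C3CC(c4ccncc4)=NO3)c[nH]c2c1` gives 12800 nM.
Compound 3 `COc1ccc2[nH]cc(C3CC(c4ccncc4)=NO3)c2c1` gives > 100000 nM, and this value is a limit, not a number.

Compound 1 and compound 2 have different cores, and the difference between the two cores is not broken down here; their values show compound 1 at the lower number, a gap beyond the usual scatter. From compound 2 to compound 3 the change is methoxy in place of hydrogen on an aromatic carbon, and it made an at least 7.8-fold higher number from compound 2 to compound 3 (0.89 log units; beyond the scatter), which rests on (the limit of > 100000 nM in this assay, at which 1 of the 3 values shown sits). Compound 4 `COc1ccc2[nH]cc(C3CC(c4cc(OC)c(OC)c(OC)c4)=NO3)c2c1` is the unmeasured partner of compound 1 carrying the same change, (methoxy in place of hydrogen on an aromatic carbon); the place is described in the same words for both pairs, so this is the same change on a different core. The step from compound 1 to compound 4 is expected to be an 8.0-fold higher number from compound 1 to compound 4 (0.90 log units; beyond the scatter), resting on an at least 7.8-fold higher number from compound 2 to compound 3 (0.89 log units; beyond the scatter). That expectation is uncertain because compound 3 sits at the limit of > 100000 nM in this assay, at which 1 of the 3 values shown sits, so the true size of the measured loss is not known. Compound 4 is therefore expected to give about 40000 nM in this assay, estimated between 10000 nM and 150000 nM.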

Compound 4, half-maximal inhibitory concentration: 71200 nM
Estimate against measurement, compound 4: 1.8-fold (0.25 log units) below; low and high end bracket the measured number.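

In this assay, putting methoxy in place of hydrogen on an aromatic carbon of the core of compound 1 made a weaker inhibitor, with a 14-fold higher number from compound 1 to compound 4 (1.15 log units; beyond the scatter). The same change also gave a weaker inhibitor on the core of compound 2, so across these two pairs the direction carried from one core to the other, but two pairs do not establish a general rule and the size of the effect cannot be compared: the same change on two cores in this assay, an at least 7.8-fold higher number (0.89 log units; beyond the scatter) from compound 2 to compound 3 and a 14-fold higher number (1.15 log units; beyond the scatter) from compound 1 to compound 4; the limit leaves it open whether they differ. For compound 3, the value is a limit and not a number: the limit of > 100000 nM in this assay, at which 1 of the 4 values shown sits.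

The compounds shown leave open whether another group at this place, such as a hydroxyl, an amine or a carboxylic acid, would also give a weaker inhibitor. They also leave open whether methoxy would have the same effect at another place on this ring or on a third core.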